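Furan-2-yl for furan-3-yl on a shared core: series notes

A few compounds are considered here, and "the series" means these few. Any claim that something is new, unique, unknown or untested is made for them only; others in the source may bear on it.

Compound 1 `Nc1nc2c(c(-c3ccco3)cn2[C@@H]2O[C@H](CO)[C@@H](O)[C@H]2O)c(=O)[nH]1` in a functional assay on K562 cells (Homo sapiens), read by MTT assay, with a stated time of 72 h (a higher number here means a weaker inhibitor, a lower number a stronger inhibitor), gives > 20000 nM, a limit of the assay.
Compound 2 `COc1nc(N)nc2c1c(-c1ccoc1)cn2[C@@H]1O[C@H](CO)[C@@H](O)[C@H]1O` in this assay gives > 20000 nM, likewise a limit of the assay.
Compound 3 `Nc1nc2c(c(-c3ccoc3)cn2[C@@H]2O[C@H](CO)[C@@H](O)[C@H]2O)c(=O)[nH]1` in this assay gives 19600 nM.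

Among the compounds with values here, the only measured step in this assay is an at least 1.0-fold higher number from compound 3 to compound 1 (0.00 log units; that floor lies within the scatter), made by the change (furan-2-yl in place of furan-3-yl on an aromatic carbon). Two of the three values sit at the limit (the limit of > 20000 nM in this assay, at which 2 of the 3 values shown sit), so the series as shown is weak throughout.

Compound 4 `COc1nc(N)nc2c1c(-c1ccco1)cn2[C@@H]1O[C@H](CO)[C@@H](O)[C@H]1O` is not yet measured. It differs from compound 2 by furan-2-yl in place of furan-3-yl on an aromatic carbon, the same change at the same place as between compound 3 and compound 1. The difference between the core of compound 2 and the core of compound 3 is not broken down here.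

The step that the limit leaves unreadable from compound 2 to compound 4 is expected to be small, resting on compound 3 and the step of an at least 1.0-fold higher number from compound 3 to compound 1 (0.00 log units; that floor lies within the scatter). Compound 4 is expected at 30000 nM, between 15000 nM and 100000 nM, and most likely reported only as a limit.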

Compound 4, half-maximal inhibitory concentration: > 20000 nM
Compound 4: a limit, no number; the forecaster's own chance of this, stated with the estimate: 85%; the middle value lies beyond the limit too.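

No step can be read between compound 2 and compound 4, as both give only a limit in this assay. The compounds shown leave open what furan-2-yl in place of furan-3-yl does on the core of compound 2: the limit of > 20000 nM in this assay, at which 3 of the 4 values shown sit.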